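The source may report more compounds than this note shows. Statements on the series, on what has been measured and on what is new or still open speak of the compounds shown alone.

In an ADME assay on J774.A1 cells (Mus musculus) for cytotoxicity, read by MTT assay, with a stated time of 72 h (on this read-out lower numbers stand for higher toxicity in this test and higher numbers for lower toxicity in this test), compound 1 `Fc1ccc(COC(CCn2ccnc2)c2ccco2)c(F)c1` gives 28800 nM, compound 2 `Fc1ccc(COC(CCn2cncn2)c2ccco2)c(F)c1` stands as "not determined" (no result reported) and compound 3 `Clc1cccc(COC(CCn2cncn2)c2ccco2)c1` gives 18600 nM. Going by the values given here, the numbers of compound 1 and compound 3 lie within the usual scatter of each other, so compound 1 cannot be told apart from the only other compound with a measured value. Compound 4 `Fc1ccc(COC(CCn2ccnc2)c2cccs2)c(F)c1` is still unmeasured. It differs from compound 1 as follows: thiophen-2-yl in place of furan-2-yl on a saturated chain carbon bound to an oxygen on a saturated carbon and a saturated chain carbon. Among the compounds with values here, no measured pair shows this swap, so the data offer no direct guide, and no step beyond the scatter is expected in this assay in either direction. The estimate amounts to a 1.2-fold lower number from compound 1 to compound 4 (0.06 log units; within the scatter), an expected step within the scatter. Compound 4 is expected at 25000 nM, with an estimated range from 12000 nM to 50000 nM.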

Compound 4, half-maximal cytotoxic concentration: 34400 nM
The estimate for compound 4 lay 1.4-fold (0.14 log units) below the measured number, within the range that was stated.
By their numbers in this assay, from the lowest: compounds 3, 1 and 4 (each within the scatter of the next).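

Placing thiophen-2-yl in place of furan-2-yl on this saturated chain carbon gives the first direct reading of a change at this position in this assay, with a 1.2-fold higher number from compound 1 to compound 4 (0.08 log units; within the scatter). In this single pair, exchanging the ring oxygen for a ring sulfur leaves the two compounds indistinguishable on this read-out. No measured information explains this result. Going by these compounds, whether a phenyl ring or a carboxylic acid at this position would move the number remains open. So does whether this swap would give an equally small step on another core.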